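Ethoxy in Place of Methyl: What Efficacy to Expect

The source may hold more compounds than are shown below. What is called first, only, known or untested is meant among the compounds shown, and "the series" means these compounds.

Compound 2 `Cc1cccc(C(=O)NCN2CCC(c3cccc[n+]3[O-])CC2)c1` shows the larger of the two responses recorded so far in a functional assay on HEK293 cells for agonist activity at D(4) dopamine receptor (Homo sapiens), read by FLIPR; a lower number here means a smaller maximal response, a higher number a larger maximal response: compound 2 gives 77%, while compound 1 `O=C(NCN1CCC(c2cccc[n+]2[O-])CC1)c1ccccc1` gives 63%. Going by the values given here, the only measured step, a number 14 percentage points higher from compound 1 to compound 2 (beyond the scatter), came from a methyl in place of hydrogen on an aromatic carbon. Compound 3 `CCOc1cccc(C(=O)NCN2CCC(c3cccc[n+]3[O-])CC2)c1` differs from compound 2 at that same carbon: ethoxy in place of methyl on an aromatic carbon. Among the compounds with values here, no measured step swaps one substituent for another at this spot, so the rise seen between compound 1 and compound 2 shows only that a small group there is tolerated; it does not say what a different, larger group will do. The expectation is therefore a change within the scatter, a number 2 percentage points lower from compound 2 to compound 3 (within the scatter), in this assay. Compound 3 is estimated to reach 75% in this assay, with a range from 55% to 95%.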

Compound 3, largest response reached (reported as efficacy), in percent of the reference or control that the assay uses: 54%
The estimate for compound 3 lay 21 percentage points above the measured number; the measured number lies below the stated range.
By their numbers in this assay, from the lowest: compounds 3 and 1 (each within the scatter of the next); then compound 2.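

In this assay the choice of group at this aromatic carbon clearly matters: the result is a number 23 percentage points lower from compound 2 to compound 3 (beyond the scatter) when ethoxy replaces methyl, so the gain seen with methyl does not extend to every group placed there. Set against hydrogen at the same carbon, ethoxy gives a number 9 percentage points lower from compound 1 to compound 3 (within the scatter) and so cannot be told apart from the compound that carries no group there, which leaves methyl as the only one of these two groups with a response beyond the scatter of the hydrogen compound. Nothing available explains why methyl and ethoxy part ways at this carbon.

On these data alone, what a methoxy or an ethyl group would do at this carbon remains open, and the pair could help separate the effect of the oxygen from that of the longer chain. As far as these compounds go, how an amine or a single fluorine atom there would compare is also open.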